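Carbonyl in place of sulfonyl on the chain nitrogen

The source may hold more compounds than are shown below. What is called first, only, known or untested is meant among the compounds shown, and "the series" means these compounds.

Measured in a functional assay on SK-MEL-28 cells (Homo sapiens) for cytotoxicity, read by MTT assay; a higher number here means a weaker inhibitor, a lower number a stronger inhibitor:
compound 1 `O=S(=O)(NCCCNc1nccc(-c2c(-c3cccc(F)c3)nc3sccn23)n1)c1ccc(Cl)cc1` gives 8450 nM
compound 2 `O=C(NCCNc1nccc(-c2c(-c3cccc(F)c3)nc3sccn23)n1)c1ccc(Cl)cc1` gives 8160 nM
compound 3 `O=S(=O)(NCCNc1nccc(-c2c(-c3cccc(F)c3)nc3sccn23)n1)c1ccccc1` gives 19000 nM

All three share one core and differ only in the group hung on the nitrogen at the end of a short saturated chain. Compound 3 shows the highest number of the three; the steps up to it are a 2.2-fold higher number from compound 1 to compound 3 (0.35 log units; beyond the scatter) and a 2.3-fold higher number from compound 2 to compound 3 (0.37 log units; beyond the scatter), both modest but beyond the scatter. The step between compound 1 and compound 2, a 1.0-fold lower number from compound 1 to compound 2 (0.02 log units; within the scatter), lies within the scatter.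

Compound 4 `O=C(NCCNc1nccc(-c2c(-c3cccc(F)c3)nc3sccn23)n1)c1ccccc1` differs from compound 3 in one place: benzoyl in place of phenylsulfonyl on an amine nitrogen. For the measured compounds named here, two measured steps bear on this. The closest is a 2.3-fold higher number from compound 2 to compound 3 (0.37 log units; beyond the scatter), the same sulfonyl-to-carbonyl exchange on the same nitrogen, run backwards, though there the carbonyl group carried a chloro substituent; the other, a 1.0-fold lower number from compound 1 to compound 2 (0.02 log units; within the scatter), also replaces a sulfonyl with a carbonyl while shortening the chain. Going back from sulfonyl to carbonyl is therefore expected to lower the number modestly, a 1.9-fold lower number from compound 3 to compound 4 (0.28 log units; within the scatter), because a 2.3-fold higher number from compound 2 to compound 3 (0.37 log units; beyond the scatter) went the other way by a similar amount. Compound 4 is estimated at 10000 nM, with a range from 4000 nM to 25000 nM.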

Compound 4, half-maximal inhibitory concentration: 17000 nM
Compound 4: middle estimate off by 1.7-fold (0.23 log units), on the low side, and the stated range covers the measured number.
By their numbers in this assay, from the lowest: compounds 2, 1, 4 and 3 (each within the scatter of the next, the first and the last beyond it).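

With a plain phenyl ring on both, exchanging phenylsulfonyl for benzoyl on the amine nitrogen makes no readable difference in this assay (a 1.1-fold lower number from compound 3 to compound 4 (0.05 log units; within the scatter)). The step that does clear the scatter is hydrogen in place of chloro on the benzoyl compounds (a 2.1-fold higher number from compound 2 to compound 4 (0.32 log units; beyond the scatter)), so among these compounds the gap between compound 2 and compound 3 follows the chloro and not the exchange of carbonyl for sulfonyl. The remaining step stays within the scatter (a 2.0-fold higher number from compound 1 to compound 4 (0.30 log units; within the scatter)), but it alters the linking group, the chain and the chloro all at once, so it cannot be pinned on any one of them.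

Nothing measured here explains why removing the chloro raises the number.

As far as these compounds go, it remains open whether the chloro counts for the same on a phenylsulfonyl group carried by the shorter chain, and whether a fluoro or a methoxy group in its place, or a simple amine at the end of the chain, would move the number at all.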